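Carboxy in place of ethyl: from compound 3 to compound 4

The source may report more compounds than this note shows. Statements on the series, on what has been measured and on what is new or still open speak of the compounds shown alone.

Of the compounds shown here, three have numbers so far in a functional assay on HUVEC cells (Homo sapiens) for inhibition, with a stated time of 4 days; a lower number here means a stronger inhibitor, a higher number a weaker inhibitor. Compound 1 `COc1ccc(C(C)=O)cc1COc1cccc(C)c1` gives 2800 nM, and compound 2 `Cc1cc(OCc2cccc(C#N)c2)ccc1Cl` gives 11000 nM. Compound 3 `CCc1ccc(OC)c(COc2ccc(Cl)c(C)c2)c1` gives 40000 nM, the highest of the three numbers and beyond the scatter of both others, which makes it the weakest inhibitor measured so far. Compound 4 `COc1ccc(C(=O)O)cc1COc1ccc(Cl)c(C)c1` carries carboxy in place of ethyl on an aromatic carbon. Among the compounds with values here, no measured pair differs in one place only, so the expectation is loose: a small move toward a lower number in this assay, probably none beyond the scatter. The expected step is a 2.0-fold lower number from compound 3 to compound 4 (0.30 log units; within the scatter). For compound 4 the estimate is 20000 nM, with an expected range of 4000 nM to 100000 nM.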

Compound 4, half-maximal inhibitory concentration: > 50000 nM
Compound 4 ended at the assay's limit; the forecaster's own chance of this, stated with the estimate: 25%; middle value at least 2.5-fold (0.39 log units) away from the limit.
By their numbers in this assay, from the lowest: compound 1; then compound 2; then compound 3. At a limit, above all of these: compound 4.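

In this assay, carboxy in place of ethyl on an aromatic carbon, para to a methoxy group, gives an at least 1.2-fold higher number from compound 3 to compound 4 (0.09 log units; that floor lies within the scatter). This change shows no move toward a lower number at this position, but its true size cannot be read, since compound 4 gives > 50000 nM, a limit of the assay and not a number. The series has one value at that limit: the limit of > 50000 nM in this assay, at which 1 of the 4 values shown sits.

Open, as far as these compounds go, is how far the true value of compound 4 lies beyond that limit. Also open, from the compounds shown here alone, is whether an amide, a primary amine or a longer chain such as propyl at this position would give a readable number.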